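The source may hold more compounds than are shown below. What is called first, only, known or untested is meant among the compounds shown, and "the series" means these compounds.

Working notes on the amine side chain. In an ADME assay on microsomes from liver (Homo sapiens) for metabolic stability, read by LC-MS, using NADPH, with a stated time of 10 min, tested at 0.5 uM (a higher number here means that more of the compound is left, a lower number that less of the compound is left), compound 2 (`CC(C)(CN)CCN(C[C@H]1Cc2ccccc2CN1)[C@H]1CCCc2cccnc21`) stands highest of the two measured compounds at 88.7%, while compound 1 (`CC(C)(CCN)CN(C[C@H]1Cc2ccccc2CN1)[C@H]1CCCc2cccnc21`) gives 76.1%.

The next compound to be read is compound 3 (`CC(C)(N)CCCN(C[C@H]1Cc2ccccc2CN1)[C@H]1CCCc2cccnc21`), which has the same atoms as compound 2, joined differently: 2-amino-2-methylpropyl in place of 1-(aminomethyl)-1-methylethyl on a saturated chain carbon, two bonds along the chain from an amine nitrogen. In words, 2-amino-2-methylpropyl stands in place of 1-(aminomethyl)-1-methylethyl on a saturated chain carbon, two bonds along the chain from an amine nitrogen.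

Among the measured compounds shown here, only one measured step bears on this change: a number 12.6 percentage points higher from compound 1 to compound 2 (beyond the scatter). That step is modest but beyond the scatter, and it also alters the same side chain. It shows that this assay can respond to a rearrangement of this chain, but a single step involving a different rearrangement gives no direction for the new one. The expected change is therefore none beyond the scatter, and the estimated step is a number 4.7 percentage points lower from compound 2 to compound 3 (within the scatter). For compound 3 the estimated value is 84%, with an expected range of 71% to 95%.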

Compound 3, percent of the compound remaining: 73.5%
Compound 3: the middle estimate sits 10.5 percentage points above what was measured; low and high end bracket the measured number.
By their numbers in this assay, from the lowest: compounds 3 and 1 (each within the scatter of the next); then compound 2.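

In this assay, 2-amino-2-methylpropyl in place of 1-(aminomethyl)-1-methylethyl on a saturated chain carbon, two bonds along the chain from an amine nitrogen, gives a number 15.2 percentage points lower from compound 2 to compound 3 (beyond the scatter) and so shows that this position responds to where the amine sits on the chain, even with the heavy atoms, donors and acceptors counted the same. The other pair of arrangements gives a number 2.6 percentage points lower from compound 1 to compound 3 (within the scatter) and leaves compound 1 and compound 3 indistinguishable here, while compound 2 is set apart from both by steps beyond the scatter. Nothing available accounts for the difference between these arrangements.

Open, as far as these compounds go, is whether the value of compound 2 is tied to its particular arrangement or would persist with a longer chain, or with the same chain without its methyl groups. Also open is how this position would read with a hydroxyl group or a carboxylic acid in place of the terminal amine, since all the compounds shown carry an amine on this side chain.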